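The source may hold more compounds than are shown below. What is called first, only, known or untested is meant among the compounds shown, and "the series" means these compounds.

Compound 1 `COc1ccc(Cl)cc1N(CC(=O)N(C1CCCCC1)C1CCCCC1)S(=O)(=O)c1ccccc1` gives 14300 nM in this read-out.
Compound 2 `COc1ccc(Cl)cc1N(CC(=O)Nc1ccccc1)S(=O)(=O)c1ccccc1` gives only a limit of the assay, > 20000 nM.
Compound 3 `COc1ccc(CNC(=O)CN(c2cc(Cl)ccc2OC)S(=O)(=O)c2ccccc2)cc1` gives only a limit of the assay, > 20000 nM.

Among the measured compounds shown here, in a functional assay on SH-SY5Y cells (Homo sapiens), read by MTT assay, with a stated time of 24 h (on this read-out lower numbers stand for an effect already at smaller amounts and higher numbers for an effect only at larger amounts of compound), compound 1 is the one compound with a number. Compound 2 returns only a limit of the assay, > 20000 nM. Compound 3 likewise returns only a limit, > 20000 nM. The change a step that the two limits leave unreadable from compound 2 to compound 3 is therefore unreadable, since both ends of it are limits. For the measured compounds named here, compound 2 stands where two of the three values sit (the limit of > 20000 nM in this assay, at which 2 of the 3 values shown sit), and nothing among the measured compounds places it any more precisely than that.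

Compound 4 `COc1cccc(NC(=O)CN(c2cc(Cl)ccc2OC)S(=O)(=O)c2ccccc2)c1` differs from compound 2 by methoxy in place of hydrogen on an aromatic carbon. Going by the values given here, no measured step bears directly on this change: the only step that starts from compound 2 cannot be read, and no other pair among the measured compounds exchanges hydrogen for methoxy on an aromatic carbon. The expectation for compound 4 therefore rests on where compound 2 stands, and the step that the limit leaves unreadable from compound 2 to compound 4 is expected to be none beyond the scatter. Compound 4 is estimated at 25000 nM, with a range from 8000 nM to 80000 nM, and the assay is expected more likely than not to report only a limit for it.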

Compound 4, half-maximal effective concentration: 17600 nM
The estimate for compound 4 lay 1.4-fold (0.15 log units) above the measured number; the measured number falls inside the stated range.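

In this assay, compound 4, which carries 3-methoxyphenyl on the amide-type nitrogen, gives a measured number of 17600 nM. Compound 2 and compound 3 returned only limits of the assay. Methoxy in place of hydrogen on the aromatic carbon gives an at least 1.1-fold lower number from compound 2 to compound 4 (0.05 log units; that floor lies within the scatter), and 3-methoxyphenyl in place of 4-methoxybenzyl gives an at least 1.1-fold lower number from compound 3 to compound 4 (0.05 log units; that floor lies within the scatter). Both steps are floors and not sizes, so the result shows a readable value at this position but no change beyond the scatter, because each step starts from a limit: the limit of > 20000 nM in this assay, at which 2 of the 4 values shown sit.

On these data alone, how large the methoxy step really is stays open, and a single substituted phenyl says nothing about whether methoxy would read the same elsewhere on that ring. As far as these compounds go, it is also open whether an amine, a carboxylic acid or a longer alkoxy chain such as butoxy in place of methoxy would move the number in this assay clearly beyond the scatter.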